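A few compounds are considered here, and "the series" means these few. Any claim that something is new, unique, unknown or untested is made for them only; others in the source may bear on it.

Two compounds share one core and differ only in the group carried on an aromatic carbon of the five-membered ring with three nitrogens. Compound 1 `O=C1O[C@H]([C@@H](O)Cn2cc(CNS(=O)(=O)c3ccc(Cl)cc3)nn2)C(OCc2ccccc2)=C1OCc1ccccc1` carries a (((4-chlorophenyl)sulfonyl)amino)methyl group there; in a functional assay on HepG2 cells (Homo sapiens) for antiproliferative activity, read by MTT assay, with a stated time of 72 h (a lower number here means a stronger inhibitor, a higher number a weaker inhibitor), compound 1 gives 7510 nM. Compound 2 `Cc1ccc(-c2cn(C[C@H](O)[C@H]3OC(=O)C(OCc4ccccc4)=C3OCc3ccccc3)nn2)cc1` carries a 4-methylphenyl group in its place; in this assay compound 2 gives 8770 nM. The step of a 1.2-fold higher number from compound 1 to compound 2 (0.07 log units; within the scatter) shows that exchanging these two quite different groups left the number essentially unchanged, so compound 2 and compound 1 lie within the scatter of each other and neither can be called the stronger of the two.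

Compound 3 `O=C1O[C@H]([C@@H](O)Cn2cc(-c3cc(F)cc(F)c3)nn2)C(OCc2ccccc2)=C1OCc1ccccc1` is the next step: 3,5-difluorophenyl in place of 4-methylphenyl on an aromatic carbon. Going by the values given here, the only measured step at this position is a 1.2-fold higher number from compound 1 to compound 2 (0.07 log units; within the scatter), and it stayed within the scatter. On that basis the step of a 1.1-fold lower number from compound 2 to compound 3 (0.04 log units; within the scatter) is expected to stay within the scatter as well, in no particular direction. Compound 3 is therefore estimated at 8000 nM in this assay, with a range from 3000 nM to 22000 nM.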

Compound 3, half-maximal inhibitory concentration: 11600 nM
Compound 3: the middle estimate sits 1.5-fold (0.16 log units) below what was measured, within the range that was stated.
By their numbers in this assay, from the lowest: compounds 1, 2 and 3 (each within the scatter of the next).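

Placing 3,5-difluorophenyl on this aromatic carbon of the five-membered aromatic ring with 3 nitrogen in place of 4-methylphenyl gives a 1.3-fold higher number from compound 2 to compound 3 (0.12 log units; within the scatter) in this assay, a step that stays within the scatter even though a fluorine-bearing ring replaces a methyl-bearing one. Set against the quite different (((4-chlorophenyl)sulfonyl)amino)methyl group, the same ring gives a 1.5-fold higher number from compound 1 to compound 3 (0.19 log units; within the scatter), so even this widest gap among compounds 1, 2 and 3 lies within the scatter, and none of the three groups can be ranked above another at this position. Nothing available here accounts for how close these numbers lie.

The compounds shown leave open whether an amine, a carboxylic acid or a longer alkyl chain on this aromatic carbon would give a number beyond the scatter. From the compounds shown here alone, all three also keep the rest of the shared core, including its two benzyloxy groups, the same, so what a change there would do in this assay remains open as well.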